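Bromo for Chloro in a Cytotoxicity Series

The source may hold more compounds than are shown below. What is called first, only, known or untested is meant among the compounds shown, and "the series" means these compounds.

Measured so far:
compound 1, `COc1ccc(-c2nnsc2SCC(=O)Nc2ccccc2Cl)cc1`: > 318000 nM
compound 2, `O=C(CSc1snnc1-c1ccccc1)Nc1ccccc1[N+](=O)[O-]`: >= 246000 nM
compound 3, `O=C(CSc1snnc1-c1ccc(Cl)cc1Cl)Nc1ccccc1F`: 19500 nM

All three were tested in an ADME assay on MT4 cells (Homo sapiens) for cytotoxicity; a higher number here means that more compound is tolerated, a lower number that less compound is tolerated. For compound 1 the value > 318000 nM is a limit of the assay, not a measured number. For compound 2 the value >= 246000 nM is also a limit. Compound 3 is the only one of the three with a measured number, 19500 nM. Compound 1 therefore stands at the limit of > 318000 nM in this assay, at which 1 of the 3 values shown sits, and a second compound stands at the limit of >= 246000 nM in this assay, at which 1 of the 3 values shown sits, so two of the three values show only where the assay stops rather than where the compounds lie.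

Compound 4, `COc1ccc(-c2nnsc2SCC(=O)Nc2ccccc2Br)cc1`, has not yet been tested. It differs from compound 1 in one place: bromo in place of chloro on an aromatic carbon. Within the data shown here, no step between two measured compounds of this kind is available here, so the expectation rests on the size of the change alone. A single halogen swap on the same aromatic carbon is expected to move the read-out in this assay by no more than the usual scatter, in no particular direction, and the result is expected again to land at the limit.

Compound 4 is estimated to give 280000 nM, with a range from 80000 nM to 450000 nM. The expected step of an at least 1.1-fold lower number from compound 1 to compound 4 (0.05 log units; that floor lies within the scatter) is small.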

Compound 4, half-maximal cytotoxic concentration: > 286000 nM
Compound 4 was reported as a limit; the forecaster's own chance of this, stated with the estimate: 65%; at least 1.0-fold (0.00 log units) between middle value and limit.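

In this assay compound 4 gives > 286000 nM, which is a limit. Compound 1 gives > 318000 nM, which is also a limit. Among these compounds, with a limit on each side, no step from chloro to bromo can be read between compound 1 and compound 4. The compounds shown leave open where either compound truly lies and whether this swap changes tolerance at all.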